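A few compounds are considered here, and "the series" means these few. Any claim that something is new, unique, unknown or untested is made for them only; others in the source may bear on it.

Within the data shown here, in a functional assay on HeLa cells (Homo sapiens) for antiproliferative activity, read by CCK-8 assay, with a stated time of 72 h, tested at 2 uM (a higher number here means a stronger effect of the compound at the concentration tested, a lower number a weaker effect), compound 1 `CN(C(=S)SCc1ccc(C(=O)Nc2ccccc2N)cc1)c1cccnc1` gives 16% and compound 2 `CN(Cc1cccnc1)C(=S)SCc1ccc(C(=O)Nc2ccccc2N)cc1` gives 16.4%; these two values lie within the scatter of each other, the only step measured being a number 0.4 percentage points higher from compound 1 to compound 2 (within the scatter). Compound 3 `Nc1ccccc1NC(=O)c1ccc(CSC(=S)N2CCCC2)cc1` differs from compound 2 by pyrrolidin-1-yl in place of methyl((pyridin-3-yl)methyl)amino on a thiocarbonyl carbon. Among the measured compounds shown here, no measured step changes the thiocarbonyl carbon's nitrogen group in this way, so the single measured step is only a loose guide; it suggests modest moves in this part of the molecule. The expected change is a number 0.6 percentage points higher from compound 2 to compound 3 (within the scatter), and for compound 3 the estimate in this assay is 17%, ranging from 5% to 35%.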

Compound 3, a percentage reported as inhibition, at one concentration (the size of the read-out at that concentration, not a potency): 51.3%
Estimate against measurement, compound 3: 34.3 percentage points below; the measured number lies above the stated range.
By their numbers in this assay, from the lowest: compounds 1 and 2 (each within the scatter of the next); then compound 3.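

The two pyridine-containing groups on the thiocarbonyl carbon left the result within the scatter, so the position first looked insensitive, yet in this assay pyrrolidin-1-yl gives a number 34.9 percentage points higher from compound 2 to compound 3 (beyond the scatter) and a number 35.3 percentage points higher from compound 1 to compound 3 (beyond the scatter). This position can therefore strongly change the effect at the concentration tested, and the outcome depends on which nitrogen group sits there. No supporting measurement explains this rise.

Going by these compounds, it remains open whether the gain follows from the pyrrolidine ring itself or simply from losing the pyridine ring. Piperidin-1-yl, morpholin-4-yl or open-chain dimethylamino groups could help separate these possibilities.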